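A few compounds are considered here, and "the series" means these few. Any claim that something is new, unique, unknown or untested is made for them only; others in the source may bear on it.

Values measured in a functional assay on U-87MG ATCC cells for antiproliferative activity against U-87 MG (Homo sapiens), read by MTT assay, with a stated time of 48 h; on this read-out lower numbers stand for stronger inhibition and higher numbers for weaker inhibition:

- compound 1 `COc1ccc(-c2nc(C)c(C(=O)CSc3nc(-c4ccc(Cl)cc4)c(C#N)c(=O)[nH]3)s2)cc1`: 45900 nM
- compound 2 `Cc1nc(-c2ccc(Cl)cc2)sc1C(=O)CSc1nc(-c2ccc(Cl)c(Cl)c2)c(C#N)c(=O)[nH]1`: 83900 nM
- compound 3 `Cc1nc(-c2ccccc2)sc1C(=O)CSc1nc(-c2ccc(Cl)c(Cl)c2)c(C#N)c(=O)[nH]1`: 65000 nM

Compound 3, at 65000 nM, lies within the scatter of both compound 2 and compound 1, so these numbers set no clear order around it. The next compound to be measured is compound 4 `Cc1nc(-c2ccccc2)sc1C(=O)CSc1nc(-c2ccc(Cl)cc2)c(C#N)c(=O)[nH]1`. It differs from compound 3 by one change, 3,4-dichlorophenyl to 4-chlorophenyl: hydrogen in place of chloro on an aromatic carbon.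

Among the measured compounds shown here, only one measured step is of the same kind, hydrogen in place of chloro on an aromatic carbon. This is a 1.3-fold lower number from compound 2 to compound 3 (0.11 log units; within the scatter), and it lies at a different place in the molecule, so it bears on the new change only by analogy. The 4-chlorophenyl group that compound 4 will carry also occurs in compound 1, at 45900 nM, although that compound differs elsewhere. Neither observation points to a shift beyond the scatter in this assay, so no such shift is expected, with only a slight lean towards a lower number. The expected change is a 1.2-fold lower number from compound 3 to compound 4 (0.07 log units; within the scatter). Compound 4 is estimated at 55000 nM, with an expected range from 27000 nM to 110000 nM.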

Compound 4, half-maximal inhibitory concentration: 43400 nM
Compound 4: the middle estimate sits 1.3-fold (0.10 log units) above what was measured; measured number inside the range.
By their numbers in this assay, from the lowest: compounds 4, 1, 3 and 2 (each within the scatter of the next).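

In this assay, the exchange of 3,4-dichlorophenyl for 4-chlorophenyl gives a 1.5-fold lower number from compound 3 to compound 4 (0.18 log units; within the scatter) and so does not separate chloro from hydrogen at this place, on an aromatic carbon ortho to a chloro group and meta to a large group. Hydrogen in place of methoxy at another place in the molecule reads the same way, with a 1.1-fold lower number from compound 1 to compound 4 (0.02 log units; within the scatter) also printed as within the scatter, and together with a 1.3-fold lower number from compound 2 to compound 3 (0.11 log units; within the scatter) this means that neither of the two aromatic rings has yet shown a substituent step that the read-out can resolve. No measured information accompanies these numbers that could explain them.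

On these data alone, what remains open is whether any group on either ring can move the number beyond the scatter, since the substituents compared so far are only hydrogen, chloro and methoxy. An amine or a carboxylic acid in place of the chloro group, or a longer alkoxy chain in place of the methoxy group, would test this, and the nitrile and the shared core remain unvaried across these compounds.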